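Three chromone amides and a fourth with a methylphenyl amide

The source may hold more compounds than are shown below. What is called first, only, known or untested is meant among the compounds shown, and "the series" means these compounds.

Measured so far:
compound 1 `COc1ccc2c(=O)c(/C=C/C(=O)Nc3ccc(Cl)cc3)coc2c1`: 272000 nM
compound 2 `Cc1ccccc1NC(=O)/C=C/c1coc2cc(O)ccc2c1=O`: 374000 nM
compound 3 `CCOc1ccc(NC(=O)/C=C/c2coc3cc(OC)ccc3c2=O)cc1`: 460000 nM

All three were tested in an ADME assay on HepG2 2.2.15 cells (Homo sapiens) for cytotoxicity, read by MTT assay, with stated times of 48 h and 9 days; a lower number here means that less compound is tolerated, a higher number that more compound is tolerated. Compound 3 gives the largest of the three numbers, but its gap to compound 2 and its gap to compound 1 are both within the scatter, so the three cannot be separated. Going by the values given here, the only step between two compounds that differ in a single place is a 1.7-fold higher number from compound 1 to compound 3 (0.23 log units; within the scatter), and it too lies within the scatter: exchanging the group on the amide-bearing ring left the tolerated concentration essentially unchanged.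

Compound 4 `COc1ccc2c(=O)c(/C=C/C(=O)Nc3ccccc3C)coc2c1` has not yet been measured. Compared with compound 3 the change is 2-methylphenyl in place of 4-ethoxyphenyl on an amide-type nitrogen. Compound 2 carries the same 2-methylphenyl on its amide nitrogen, though it differs from compound 4 elsewhere in the shared core, and in this assay compound 2 gives 374000 nM, a number close to that of compound 3.

With one single-point step available and that step within the scatter, no change beyond the scatter is expected for compound 4 in this assay: the step of a 1.2-fold lower number from compound 3 to compound 4 (0.09 log units; within the scatter) is the estimate. Compound 4 is therefore expected to give about 370000 nM, in the range 200000 nM to 650000 nM.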

Compound 4, half-maximal cytotoxic concentration: 59700 nM
Compound 4: the middle estimate sits 6.2-fold (0.79 log units) above what was measured; measured number outside the range, below it.
By their numbers in this assay, from the lowest: compound 4; then compounds 1, 2 and 3 (each within the scatter of the next).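

In this assay, placing 2-methylphenyl on the amide-type nitrogen gives a clear drop in the tolerated concentration: replacing 4-ethoxyphenyl gives a 7.7-fold lower number from compound 3 to compound 4 (0.89 log units; beyond the scatter) and replacing 4-chlorophenyl gives a 4.6-fold lower number from compound 1 to compound 4 (0.66 log units; beyond the scatter) as the change. Going by these compounds alone, the earlier exchange at the far end of the amide, a 1.7-fold higher number from compound 1 to compound 3 (0.23 log units; within the scatter) as its only step, stayed within the scatter, so this position is not as indifferent to change as that step suggested. The 2-methylphenyl group does not bring the low number by itself, however: compound 2 carries it too, and adding a methyl in place of the hydrogen on the ring oxygen gives a 6.3-fold lower number from compound 2 to compound 4 (0.80 log units; beyond the scatter) as the result, so among these compounds the low number appears only when 2-methylphenyl and the methoxy-bearing core occur together.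

Going by these compounds, it remains open whether a 2-ethylphenyl or a 2-aminophenyl group on the same nitrogen would give a similarly low number, and whether the drop extends beyond this single compound. Nothing available here explains why the number falls for this combination.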